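This account rests on a few compounds, and the source may have more. Where it says the series, first, only, none or still open, it means among the compounds named here.

Compound 2 `Cc1ccccc1CCCN1CC=C(CCC(=O)NO)C1=O` in a functional assay on ACHN cells (Homo sapiens) for inhibition, read by sulforhodamine B assay (on this read-out higher numbers stand for weaker inhibition of growth and lower numbers for stronger inhibition of growth), gives 3330 nM. In this assay compound 1 `O=C(CCC1=CCN(CCCc2ccc(Br)cc2)C1=O)NO` gives 3330 nM, and the step of no change at the digits printed from compound 1 to compound 2 (within the scatter) leaves compound 2 level with compound 1. Compound 3 `Cc1cccc(CCCN2CC=C(CCC(=O)NO)C2=O)c1` differs from compound 2 by 3-methylphenyl in place of 2-methylphenyl on a saturated chain carbon, three bonds along the chain from an amide-type nitrogen in a ring. Within the data shown here, the only measured step, from compound 1 to compound 2, also swapped the aryl group at this place and produced no change beyond the scatter; a swap of 2-methylphenyl for 3-methylphenyl has not itself been measured. Compound 3 is therefore expected to sit within the scatter of compound 2, an estimated step of a 1.0-fold lower number from compound 2 to compound 3 (0.00 log units; within the scatter). For compound 3 the estimate is 3300 nM, with a range of 1500 nM to 7500 nM.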

Compound 3, concentration for 50% growth inhibition: 3330 nM
Compound 3: middle estimate off by 1.0-fold (0.00 log units), on the low side, and the stated range covers the measured number.
By their numbers in this assay, from the lowest: compounds 1, 2 and 3 (each within the scatter of the next).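

In this assay, the methyl shift now has a direct reading: 3-methylphenyl in place of 2-methylphenyl gives no change at the digits printed from compound 2 to compound 3 (within the scatter), and 3-methylphenyl in place of 4-bromophenyl gives no change at the digits printed from compound 1 to compound 3 (within the scatter). All three aryl groups on this saturated chain carbon, three bonds along the chain from an amide-type nitrogen in a ring, therefore read alike, and no compound shown goes against this. Nothing on hand offers an explanation for this sameness. Open, as far as these compounds go, is whether a phenyl carrying an amine or a carboxylic acid, or a longer chain at this place, would leave the number unchanged.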